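A pyridine isomer of compound 2

A few compounds are considered here, and "the series" means these few. Any claim that something is new, unique, unknown or untested is made for them only; others in the source may bear on it.

compound 1 `O=c1ncn(Cc2ccc(Br)cc2F)c2ccc(Oc3ncccc3C(F)(F)F)cc12`: 3.6 ug/mL
compound 2 `O=c1ncn(Cc2ccc(F)cc2F)c2ccc(Oc3ncccc3C(F)(F)F)cc12`: 19 ug/mL

For the measured compounds named here, in a physicochemical assay for solubility, using the shake flask method, with a stated time of 24 h, at pH 2 (on this read-out higher numbers stand for higher solubility and lower numbers for lower solubility), compound 2, at 19 ug/mL, holds the higher of the two numbers so far, and compound 1 stands at 3.6 ug/mL. The next compound to be measured is compound 3 `O=c1ncn(Cc2ccc(F)cc2F)c2ccc(Oc3cccnc3C(F)(F)F)cc12`, which has the same atoms as compound 2, joined differently: 2-(trifluoromethyl)pyridin-3-yl in place of 3-(trifluoromethyl)pyridin-2-yl on an oxygen on an aromatic ring. In words, 2-(trifluoromethyl)pyridin-3-yl stands in place of 3-(trifluoromethyl)pyridin-2-yl on an oxygen on an aromatic ring. Going by the values given here, the only measured step, a 5.3-fold higher number from compound 1 to compound 2 (0.72 log units; beyond the scatter), is fluoro in place of bromo on an aromatic carbon. That is a different change at a different place, so it shows only that a single replacement can move this number beyond the scatter. Among the compounds with values here, no measured step covers the present change, and no shift beyond the scatter is expected in either direction, so the estimated step is a 1.2-fold lower number from compound 2 to compound 3 (0.07 log units; within the scatter). In this assay the expected value for compound 3 is 16 ug/mL, with an estimated range from 6 ug/mL to 45 ug/mL.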

Compound 3, solubility: 410 ug/mL
Compound 3: the middle estimate sits 26-fold (1.41 log units) below what was measured, outside the stated range (above it).
By their numbers in this assay, from the lowest: compound 1; then compound 2; then compound 3.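

In this assay, the place on an oxygen on an aromatic ring proved highly sensitive to how the same atoms are joined: exchanging 3-(trifluoromethyl)pyridin-2-yl for 2-(trifluoromethyl)pyridin-3-yl gives a 22-fold higher number from compound 2 to compound 3 (1.33 log units; beyond the scatter) and so moves the number well beyond the scatter. The two groups match in every count computed for them, including heavy atoms, ring type and hydrogen-bond acceptors, so those counts do not separate the two compounds. No measurement here bears on what lies behind this difference.

Going by these compounds, whether the same exchange would raise the number in the bromo compound 1 remains open. It is also unknown how the number would respond if a nitrile or a methyl group stood in place of the trifluoromethyl group on the 2-(trifluoromethyl)pyridin-3-yl ring.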